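Cytotoxicity notes on a brominated sesquiterpene-phenol series

This account rests on a few compounds, and the source may have more. Where it says the series, first, only, none or still open, it means among the compounds named here.

Measured compounds:
Compound 1 `C=C1CC[C@H]2C(C)(C)[C@@H](Br)CC[C@]2(C)[C@@H]1Cc1cc(O)c(C=O)cc1O` gives in an ADME assay on MT2 cells (Homo sapiens) for cytotoxicity, read by XTT assay (on this read-out higher numbers stand for lower toxicity in this test and lower numbers for higher toxicity in this test), compound 1 4000 nM.
Compound 2 `C=C1CC[C@@H]2C(C)(C)[C@@H](Br)CC[C@]2(C)[C@H]1Cc1cc(O)c(C=O)cc1O` gives in this assay compound 2 4000 nM.
Compound 3 `CC1=CC[C@H]2C(C)(C)[C@@H](Br)CC[C@]2(C)[C@@H]1Cc1cc(O)c(CC(=O)O)cc1O` gives in this assay compound 3 > 100000 nM, which is a limit of the assay and not a number.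

Among the compounds with values here, compound 3 is thus the one member with only a limit in this assay, and the two numbered values lie at compound 1 and compound 2, which sit together. Within the data shown here, the one measured step, no change at the digits printed from compound 1 to compound 2 (within the scatter), concerns only configuration as drawn, as the fact that compounds 1 and 2 differ only in the configuration as drawn states, and gives no guidance on a change of group.

Compound 4 `CC1=CC[C@H]2C(C)(C)[C@@H](Br)CC[C@]2(C)[C@@H]1Cc1cc(O)c(C=O)cc1O` is to be measured in this assay. The change is formyl in place of carboxymethyl on an aromatic carbon. Compound 1 and compound 2 carry a formyl at that position, and both give a numbered value, while compound 3 with carboxymethyl reaches (the limit of > 100000 nM in this assay, at which 1 of the 3 values shown sits). The step of an at least 20-fold lower number from compound 3 to compound 4 (1.30 log units; beyond the scatter) is therefore expected to run towards the numbered values, downward from the limit. For compound 4 an estimate of 5000 nM is expected, within 1500 nM to 30000 nM.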

Compound 4, half-maximal cytotoxic concentration: 4000 nM
Beside the measured number, compound 4's estimate is 1.3-fold (0.10 log units) above it, and the stated range covers the measured number.
By their numbers in this assay, from the lowest: compounds 1, 2 and 4 (each within the scatter of the next). At a limit, above all of these: compound 3.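

Formyl in place of carboxymethyl on an aromatic carbon gives an at least 25-fold lower number from compound 3 to compound 4 (1.39 log units; beyond the scatter) in this assay as the first comparison in which only this position changes. Compound 3 remains a limit of the assay and not a number: the limit of > 100000 nM in this assay, at which 1 of the 4 values shown sits. With formyl at this position, compound 1 gives 4000 nM and compound 4 gives 4000 nM despite the different placement of the double bond in the shared core, so these two values show no separation.

The compounds shown leave open how large the step truly is, since only one end of it is a number. They also leave open whether a carboxylic acid set directly on the aromatic carbon, or an aminomethyl group there, would read like formyl or like carboxymethyl.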